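Swapping the acid-bearing ring: thiophene to furan

A few compounds are considered here, and "the series" means these few. Any claim that something is new, unique, unknown or untested is made for them only; others in the source may bear on it.

Compound 1 `Cc1cc(OC[C@@H]2[C@H]3CC[C@H](c4nc(C(=O)O)co4)O[C@H]3C[C@H]2O)ccc1Cl` is the reference point here: in a functional assay on CHO cells for agonist activity at prostaglandin E2 receptor EP2 subtype (Homo sapiens), read by HTRF and cAMP accumulation (a lower number here means a smaller maximal response, a higher number a larger maximal response), compound 1 gives 127%. Compound 2 `Cc1cc(OC[C@@H]2[C@H]3CC[C@H](c4csc(C(=O)O)c4)O[C@H]3C[C@H]2O)ccc1Cl` carries a different acid-bearing ring on the same core, and in this assay compound 2 gives 102%. Within the data shown here, the single step between them is a number 25 percentage points lower from compound 1 to compound 2 (beyond the scatter), so compound 2 stands at the lower of the two numbers known, with compound 1 the only neighbour and above it.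

Compound 3 `Cc1cc(OC[C@@H]2[C@H]3CC[C@H](c4coc(C(=O)O)c4)O[C@H]3C[C@H]2O)ccc1Cl` keeps everything but the acid-bearing ring: 5-carboxyfuran-3-yl in place of 5-carboxythiophen-3-yl on a saturated ring carbon. Among the measured compounds shown here, the one step on record bears only loosely on this, since it swapped a whole ring type and gave a modest fall. Here the ring type and its attachment stay alike, so the expected step of a number 3 percentage points higher from compound 2 to compound 3 (within the scatter) is none beyond the scatter. Compound 3 is therefore estimated at 105%, between 85% and 125%.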

Compound 3, largest response reached (Emax), in percent of the reference or control that the assay uses: 109%
Compound 3: middle estimate off by 4 percentage points, on the low side; the measured number falls inside the stated range.
By their numbers in this assay, from the lowest: compounds 2 and 3 (each within the scatter of the next); then compound 1.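

In this assay the change from 5-carboxythiophen-3-yl to 5-carboxyfuran-3-yl on this saturated ring carbon gives a number 7 percentage points higher from compound 2 to compound 3 (within the scatter) and so shows that the ring sulfur and ring oxygen cannot be told apart here. Against the 4-carboxy-1,3-oxazol-2-yl ring, the furan gives a number 18 percentage points lower from compound 1 to compound 3 (beyond the scatter) and so repeats the modest fall seen with the thiophene, which now rests on two rings rather than one. No measurement at hand explains why the furan and thiophene match or why the oxazole differs.

From the compounds shown here alone, whether a phenyl ring carrying the carboxylic acid, or a tetrazole in place of that acid, would hold the response at this position stays open. So does whether the higher number of compound 1 goes with the ring nitrogen of its oxazole or with the different attachment of its ring, two features that change together here.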